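One Amide Swap, Read Across Two Side Chains

This account rests on a few compounds, and the source may have more. Where it says the series, first, only, none or still open, it means among the compounds named here.

Compound 1 `CNC(=O)CCc1ccc(NC(=O)Nc2ccc(Cl)c(C(F)(F)F)c2)cc1` gives 25200 nM in a functional assay on A-375 cells (Homo sapiens) for inhibition, read by MTT assay, with a stated time of 120 h; on this read-out higher numbers stand for weaker inhibition and lower numbers for stronger inhibition. Compound 2 `C/C(=C\C(=O)N1CC(C)OC(C)C1)c1ccc(NC(=O)Nc2ccc(Cl)c(C(F)(F)F)c2)cc1` gives 46200 nM in this assay. Compound 3 `CNC(=O)/C=C(\C)c1ccc(NC(=O)Nc2ccc(Cl)c(C(F)(F)F)c2)cc1` reaches only > 50000 nM in this assay, which is a limit of the measurement and not a number.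

Compound 4 `CC1CN(C(=O)CCc2ccc(NC(=O)Nc3ccc(Cl)c(C(F)(F)F)c3)cc2)CC(C)O1` has not yet been measured in this assay. It differs from compound 1 by 2,6-dimethylmorpholin-4-yl in place of methylamino on a carbonyl carbon. The same change has already been made between two measured compounds: compound 3 becomes compound 2 by 2,6-dimethylmorpholin-4-yl in place of methylamino on a carbonyl carbon, and the measured step was an at least 1.0-fold lower number from compound 3 to compound 2 (0.03 log units; that floor lies within the scatter). The size of that step is only a floor, since compound 3 sits at the limit of > 50000 nM in this assay, at which 1 of the 3 values shown sits. The surroundings of the change are not identical: in compound 3 the carbonyl carbon's other neighbour is a double-bonded chain carbon, while in compound 1 it is a saturated chain carbon, so the change is the same kind of change rather than the same. The two cores themselves differ by 2-(methylcarbamoyl)ethyl in place of 1-methyl-2-(methylcarbamoyl)ethenyl on an aromatic carbon, and from compound 1 to compound 3 the measured step was an at least 1.9-fold higher number from compound 1 to compound 3 (0.29 log units; that floor lies within the scatter).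

The step expected here is a 1.2-fold higher number from compound 1 to compound 4 (0.08 log units; within the scatter), resting on the measured step of an at least 1.0-fold lower number from compound 3 to compound 2 (0.03 log units; that floor lies within the scatter), which lies within the scatter and therefore points to little movement. Compound 4 is accordingly estimated at 30000 nM, with a plausible range from 10000 nM to 80000 nM.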

Compound 4, half-maximal inhibitory concentration: > 50000 nM
Compound 4 gave a limit, no number; the forecaster's own chance of this, stated with the estimate: 25%; middle value at least 1.6-fold (0.22 log units) from the limit.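

In this assay compound 4 gives > 50000 nM, which is a limit of the measurement and not a number. Putting 2,6-dimethylmorpholin-4-yl in place of methylamino on the saturated side chain gives an at least 1.9-fold higher number from compound 1 to compound 4 (0.29 log units; that floor lies within the scatter), and this step can be compared with the same change on the double-bonded side chain only in part: the same change on two cores in this assay, an at least 1.0-fold lower number (0.03 log units; that floor lies within the scatter) from compound 3 to compound 2 and an at least 1.9-fold higher number (0.29 log units; that floor lies within the scatter) from compound 1 to compound 4; the limit leaves it open whether they differ. The two cores therefore give no evidence that the change carries over unaltered, and none that it behaves differently on each, since the true size of both steps remains hidden at the limit: the limit of > 50000 nM in this assay, at which 2 of the 4 values shown sit.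

The compounds shown leave open what other groups would do in place of methylamino on the carbonyl carbon, such as an unsubstituted morpholine, a simple amine such as dimethylamino, or a hydroxyl group that would turn the amide into a carboxylic acid. They also leave open whether a longer chain in place of the 2-(methylcarbamoyl)ethyl side chain would change the picture, and a series with numbers on both sides of the change would be needed before any size could be carried from one core to another.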